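The source may report more compounds than this note shows. Statements on the series, on what has been measured and on what is new or still open speak of the compounds shown alone.

Measured compounds in a functional assay on HL-60 cells (Homo sapiens) for cytotoxicity, read by MTT assay, with a stated time of 48 h; a lower number here means a stronger inhibitor, a higher number a weaker inhibitor:
compound 1 `COc1ccc(Nc2n[n+]([O-])c3ccccc3[n+]2[O-])cc1` gives 900 nM
compound 2 `CCCCCCCCNc1n[n+]([O-])c2ccccc2[n+]1[O-]` gives 7200 nM
compound 3 `CCN(CC)c1n[n+]([O-])c2ccccc2[n+]1[O-]` gives > 49000 nM, which is a limit of the assay and not a number

All three share one core and differ only in what sits on the nitrogen attached to it. Among the two numbers actually measured, compound 2 stands highest, that is, it is the weaker inhibitor of the pair. Its nearest neighbour is compound 1, whose number is lower by a gap beyond the usual scatter. Compound 3 sits at the assay limit (the limit of > 49000 nM in this assay, at which 1 of the 3 values shown sits), so it gives no number to compare.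

Compound 4 `[O-][n+]1nc(NCc2ccccc2Cl)[n+]([O-])c2ccccc21` has not yet been measured in this assay. It differs from compound 2 in one place:

2-chlorophenyl in place of heptyl on a saturated chain carbon bound to a nitrogen on an aromatic ring

An aromatic group on the nitrogen, as in compound 1 with its value of 900 nM, went with a lower number than the long chain of compound 2, and compound 4 also carries an aromatic group, though one carbon further from the nitrogen. The step from compound 2 to compound 4 is therefore expected to go downward, most likely by a modest amount, as a 2.9-fold lower number from compound 2 to compound 4 (0.46 log units; beyond the scatter) expresses. Compound 4 is estimated to give about 2500 nM, with a range from 600 nM to 10000 nM.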

Compound 4, half-maximal inhibitory concentration: 5800 nM
Compound 4: middle estimate off by 2.3-fold (0.37 log units), on the low side; the measured number falls inside the stated range.
By their numbers in this assay, from the lowest: compound 1; then compounds 4 and 2 (each within the scatter of the next). At a limit, above all of these: compound 3.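

In this assay, the change at this one place gives a 1.2-fold lower number from compound 2 to compound 4 (0.09 log units; within the scatter) and so leaves the two compounds indistinguishable. This position therefore accepts either a chain with no ring or a chlorine-bearing aromatic ring, each with the same count of heavy atoms, with no readable change in the number. The earlier compounds shown here could not show this: they left open whether an aromatic ring in this group would be enough to lower the number, and here, on this chain carbon, the ring alone is not enough.

As far as these compounds go, how a phenyl ring without the chlorine, or a chain ending in an amine or a carboxylic acid, would behave at this place remains open. Nothing available here accounts for why the chain and the chlorine-bearing ring give numbers that cannot be told apart.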